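Replacing One Large Group on the Amine Nitrogen

The compounds below may be only part of what the source reports. "The series", "measured", "known", "first", "only" and "open" are said of these compounds alone.

Of the compounds shown here, two with a shared core have been measured in a functional assay on HeLa cells (Homo sapiens) for inhibition, read by MTT assay, with a stated time of 48 h; on this read-out lower numbers stand for stronger inhibition and higher numbers for weaker inhibition. Compound 1 `CCOC(=O)C1=C(N)Nc2[nH]nc(C)c2C1c1ccc(N(C)C)cc1` gives 6220 nM, while compound 2 `CCOC(=O)C1=C(N/N=C(/C(=O)Br)c2ccc(Cl)cc2)Nc2[nH]nc(C)c2C1c1ccc(N(C)C)cc1` gives 49300 nM, the higher of the two numbers and therefore the weaker inhibition. Compound 3 `CCOC(=O)C1=C(N/N=C(/C(C)=O)C(=O)OCC)Nc2[nH]nc(C)c2C1c1ccc(N(C)C)cc1` has not been measured yet. It keeps the core of compound 2 and differs only in the group on an amine nitrogen whose other neighbour is a double-bonded ring carbon: a group of 10 heavy atoms (6 carbon, 1 nitrogen, 3 oxygen; no ring) in place of a group of 12 heavy atoms (8 carbon, 1 nitrogen, 1 oxygen, 1 chlorine, 1 bromine; one six-membered aromatic ring of carbon only), on an amine nitrogen.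

Within the data shown here, only one measured step bears on this change, a 7.9-fold higher number from compound 1 to compound 2 (0.90 log units; beyond the scatter), in which a large group took the place of a hydrogen atom. That step is modest, but it compares a large group with a hydrogen atom, whereas compound 3 swaps one large group for another. No measurement compares two such groups directly, so only a small move towards a lower number is expected. The estimated change is a 1.6-fold lower number from compound 2 to compound 3 (0.22 log units; within the scatter). For compound 3 the expected value is 30000 nM, with an estimated range from 10000 nM to 90000 nM.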

Compound 3, half-maximal inhibitory concentration: > 100000 nM
Compound 3: only a limit was reported; the forecaster's own chance of this, stated with the estimate: 10%; middle value at least 3.3-fold (0.52 log units) away from the limit.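

In this assay compound 3 gives only a limit of the assay rather than a number: the limit of > 100000 nM in this assay, at which 1 of the 3 values shown sits. Even so, the swap on the amine nitrogen can be read as an at least 2.0-fold higher number from compound 2 to compound 3 (0.30 log units; that floor lies within the scatter), so exchanging one large group for another did not bring the lower number that the opening estimate leaned towards, although this floor alone cannot separate the two compounds and the true gap could be much wider. Measured from the hydrogen atom, the new group gives an at least 16-fold higher number from compound 1 to compound 3 (1.20 log units; beyond the scatter), a step beyond the scatter, and with a 7.9-fold higher number from compound 1 to compound 2 (0.90 log units; beyond the scatter) this means that both large groups on this nitrogen, despite their different make-up, go with weaker inhibition than the hydrogen atom, with no compound shown going against that.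

The compounds shown leave open whether a much smaller group on this nitrogen, such as a methyl or an acetyl group, would stay close to compound 1. They also leave open which part of the group of 10 heavy atoms goes with the loss, and whether an amine or a carboxylic acid at the end of such a group would change the picture.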